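From pyridin-3-yl to 4-chlorophenyl on the shared core

The source may hold more compounds than are shown below. What is called first, only, known or untested is meant among the compounds shown, and "the series" means these compounds.

Values from an ADME assay on BJ cells (Homo sapiens) for cytotoxicity, with a stated time of 72 h (on this read-out lower numbers stand for an effect already at smaller amounts and higher numbers for an effect only at larger amounts of compound), follow
Compound 1 `Nc1nc(-c2ccccc2)nn1-c1ncnc2ccccc12` reaches only the limit > 50000 nM
Compound 2 `COc1cc2ncnc(-n3nc(-c4ccccn4)nc3N)c2cc1[N+](=O)[O-]` reaches only the limit > 13000 nM
Compound 3 `COc1cc2ncnc(-n3nc(-c4cccnc4)nc3N)c2cc1OC` reaches only the limit > 71000 nM

None of these three compounds has yielded a number. Compound 3 stands at a limit (> 71000 nM) and gives no exact starting point. Compound 4 `COc1cc2ncnc(-n3nc(-c4ccc(Cl)cc4)nc3N)c2cc1OC` carries 4-chlorophenyl in place of pyridin-3-yl on an aromatic carbon. Going by the values given here, no measured pair here differs in one place, so the size of the step is uncertain. A modest downward step is expected (an at least 2.3-fold lower number from compound 3 to compound 4 (0.37 log units; beyond the scatter)), and this assay may again report only a limit. For compound 4 the expected value is 30000 nM (estimated range 6000 nM to 90000 nM).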

Compound 4, half-maximal effective concentration: > 50000 nM
Compound 4: only a limit was reported (the forecaster's own chance of this, stated with the estimate: 60%); middle value at least 1.6-fold (0.22 log units) away from the limit.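

In this assay, compound 3 and compound 4 each reach only a limit, not a number, and the step between them cannot be read. The compounds shown leave open at what concentration any of them reaches a half-maximal effect.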